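Swapping Propoxy for Propylamino on a Carbonyl Carbon

This account rests on a few compounds, and the source may have more. Where it says the series, first, only, none or still open, it means among the compounds named here.

In a functional assay on cells (Platelet, Homo sapiens) for inhibition (a higher number here means a weaker inhibitor, a lower number a stronger inhibitor), compound 1 (`CCOC(=O)c1ccc(-c2nn(Cc3ccc(OC)cc3)c3ccccc23)cc1`) gives 620 nM, and compound 2 (`CCCn1nc(-c2ccc(C(=O)OCC)cc2)c2ccccc21`) gives 490 nM. Compound 3 (`CCCOC(=O)c1ccc(-c2nn(Cc3ccccc3)c3ccccc23)cc1`) gives > 10000 nM, which is a limit of the assay and not a number. Going by the values given here, it is the only compound in this small set at that limit, as the limit of > 10000 nM in this assay, at which 1 of the 3 values shown sits, records.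

The next compound, compound 4 (`CCCNC(=O)c1ccc(-c2nn(Cc3ccccc3)c3ccccc23)cc1`), differs from compound 3 at one place: propylamino in place of propoxy on a carbonyl carbon. In words, propylamino stands in place of propoxy on a carbonyl carbon.

Among the compounds with values here, the only measured step is a 1.3-fold lower number from compound 1 to compound 2 (0.10 log units; within the scatter). That change lies elsewhere in the molecule, so it says little about the carbonyl carbon. Within the data shown here, no measured step touches that place, which leaves the size of this step poorly defined. The starting point is also only a limit, so any step from it is uncertain. With nothing pointing to a clear gain, the expectation is no firm shift in this assay, and compound 4 should stay weak, close to the limit. The expected change is a number no higher from compound 3 to compound 4 (the limit leaves the size open), and this is only an estimate. For compound 4 the estimated value is 10000 nM, with an expected range from 3000 nM to 30000 nM.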

Compound 4, half-maximal inhibitory concentration: > 10000 nM
Compound 4: only a limit was reported; the forecaster's own chance of this, stated with the estimate: 60%; the middle value lies on the limit itself.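

In this assay compound 4 gives > 10000 nM as a limit of the assay and not a number. Going by these compounds alone, compound 3 also stands at a limit, so no step from compound 3 to compound 4 can be read. The compounds shown leave open whether propylamino in place of propoxy on a carbonyl carbon changes inhibition at all, and this limit recurs here: the limit of > 10000 nM in this assay, at which 2 of the 4 values shown sit.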